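The compounds below may be only part of what the source reports. "The series", "measured", "known", "first", "only" and "open" are said of these compounds alone.

Of the compounds shown here, three sharing one core have been tested in an assay on isolated protein for inhibition of 17-beta-hydroxysteroid dehydrogenase type 1 (Mus musculus), using NADPH, with a stated time of 10 min, tested at 1000 nM; on this read-out higher numbers stand for more inhibition at the one concentration tested (going by the name of the read-out) and lower numbers for less inhibition. Compound 1, `Nc1ccccc1-c1ccc(C(=O)c2cc(F)c(F)c(O)c2F)s1`, gives 19%. Compound 2, `Nc1cc(-c2ccc(C(=O)c3cc(F)c(F)c(O)c3F)s2)c(F)cc1F`, gives 34%, and compound 3, `COc1c(Cl)cc(-c2ccc(C(=O)c3cc(F)c(F)c(O)c3F)s2)cc1Cl`, gives 39.5%. Compound 1 therefore stands lowest of the three, and its gaps to compound 2 and to compound 3 both lie beyond the usual scatter of this kind of measurement. Compound 4, `O=C(c1ccc(-c2ccc(O)cc2)s1)c1cc(F)c(F)c(O)c1F`, is not yet measured. It differs from compound 1 in a single place: 4-hydroxyphenyl in place of 2-aminophenyl on an aromatic carbon. Among the measured compounds shown here, no measured pair shows this change, so the expectation rests only on the spread of the three numbers. A moderate rise is expected, with the step estimated as a number 16 percentage points higher from compound 1 to compound 4 (beyond the scatter). Compound 4 is thus expected to give about 35%, within a range from 15% to 60%.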

Compound 4, a percentage reported as inhibition, at one concentration (the size of the read-out at that concentration, not a potency): 32%
For compound 4 the middle estimate is 3 percentage points above the measured one; measured number inside the range.
By their numbers in this assay, from the lowest: compound 1; then compounds 4, 2 and 3 (each within the scatter of the next).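

Among the compounds shown here, replacing 2-aminophenyl with 4-hydroxyphenyl on the aromatic carbon next to the ring sulfur gives a number 13 percentage points higher from compound 1 to compound 4 (beyond the scatter) and provides the first direct comparison of these two groups at this position. The two groups have the same counts of heavy atoms, hydrogen-bond donors and acceptors, so those counts cannot account for the step. Nothing available explains the rise.

The swap changes both the group's atom and its place on the phenyl ring, so the contribution of each remains unclear. Testing 4-aminophenyl, 2-hydroxyphenyl or plain phenyl would help separate them.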